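This account rests on a few compounds, and the source may have more. Where it says the series, first, only, none or still open, it means among the compounds named here.

The measured compounds so far:

Compound 1, `COc1cc(C[C@H]2C(=O)OC[C@@H]2Cc2ccccc2)ccc1O`, gives 93000 nM in a functional assay on HL-60 cells (Homo sapiens) for cytotoxicity, read by WST assay, with a stated time of 48 h; on this read-out higher numbers stand for an effect only at larger amounts of compound and lower numbers for an effect already at smaller amounts.

Compound 3, `Oc1ccc(C[C@H]2COC[C@@H]2Cc2ccc(Cl)c(Cl)c2)cc1`, gives 31000 nM in this assay.

Compound 2, `COc1ccc(C[C@H]2C(=O)OC[C@@H]2Cc2ccccc2)cc1OC`, gives > 100000 nM in this assay, which is a limit of the assay and not a number.

Compound 1 and compound 2 share one core and differ in a single place: methyl in place of hydrogen on an oxygen on an aromatic ring. The step between them, an at least 1.0-fold higher number from compound 1 to compound 2 (0.03 log units; that floor lies within the scatter), is known only as a floor, because of the limit of > 100000 nM in this assay, at which 1 of the 3 values shown sits. The methyl therefore did not bring the number down; whether it pushed it up, and by how much, cannot be read from these two values alone.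

Compound 3 rests on another core; the difference between the two cores is not broken down here. Compound 3 gives 31000 nM, a lower number than compound 1 with 93000 nM.

Compound 4, `COc1ccc(C[C@H]2COC[C@@H]2Cc2ccc(Cl)c(Cl)c2)cc1`, has not yet been measured. It differs from compound 3 by methyl in place of hydrogen on an oxygen on an aromatic ring, the same change as from compound 1 to compound 2, at a place described in the same words. For compound 4 the step of a 1.9-fold higher number from compound 3 to compound 4 (0.29 log units; within the scatter) is expected. That expectation rests on the step from compound 1 to compound 2, an at least 1.0-fold higher number from compound 1 to compound 2 (0.03 log units; that floor lies within the scatter), where the same change gave no lower number. Compound 4 is thus estimated at 60000 nM, most likely between 25000 nM and 150000 nM.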

Compound 4, half-maximal effective concentration: 39000 nM
Compound 4: the middle estimate sits 1.5-fold (0.19 log units) above what was measured, within the range that was stated.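

Replacing the hydrogen on the oxygen with a methyl, which turns hydroxy into methoxy, gives a 1.3-fold higher number from compound 3 to compound 4 (0.10 log units; within the scatter) in this assay, so on this core the change produces no effect that can be told apart from the ordinary spread of repeated measurements. Setting the two cores side by side gives this picture: the same change on two cores in this assay, an at least 1.0-fold higher number (0.03 log units; that floor lies within the scatter) from compound 1 to compound 2 and a 1.3-fold higher number (0.10 log units; within the scatter) from compound 3 to compound 4; the limit leaves it open whether they differ The result on the core of compound 3 is therefore a real number that shows no clear effect, whereas the result on the core of compound 1 is only a floor, and two pairs of compounds cannot establish that the change carries over from one core to another in the same way.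

The compounds shown leave open what other groups on this oxygen would do, such as an ethyl or a longer chain, or a chain ending in an amine or a carboxylic acid. Also open is whether the swap from hydroxy to methoxy would read the same way in a compound with a much lower number than any shown here.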